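The compounds below may be only part of what the source reports. "The series", "measured", "known", "first", "only" and "open" are said of these compounds alone.

Measured compounds in this series:

- compound 1, `O=C(CCCCCCNC(=O)C(O)(O)C(F)(F)F)Nc1ccc(Cl)cc1`: 52000 nM
- compound 2, `O=C(CCCCCCNC(=O)C(O)(O)C(F)(F)F)Nc1ncc(-c2ccccc2)s1`: 21000 nM

In an assay on isolated protein for inhibition of histone deacetylase 8 (Homo sapiens), read by chemiluminescence, with a stated time of 3 h (on this read-out lower numbers stand for stronger inhibition and higher numbers for weaker inhibition), compound 1 gives the highest of the two numbers recorded; compound 2 gives the nearer and lower number, and the gap between them is beyond the usual scatter.

Compound 3, `O=C(CCCCCCNC(=O)C(O)(O)C(F)(F)F)Nc1ccc(-c2ccccc2)cc1`, remains to be measured in this assay. It differs from compound 1 in one place: phenyl in place of chloro on an aromatic carbon. Compound 2 also carries a phenyl on its aromatic ring, though on a different core, so the pair of measured values offers only a loose pointer.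

Given that compound 2 gives 21000 nM in this assay, a moderate move toward a lower number is expected for compound 3, with the step of a 2.1-fold lower number from compound 1 to compound 3 (0.32 log units; beyond the scatter) likely just beyond the scatter. For compound 3 the estimate in this assay is 25000 nM, with a range from 8000 nM to 80000 nM.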

Compound 3, half-maximal inhibitory concentration: 4100 nM
The estimate for compound 3 lay 6.1-fold (0.79 log units) above the measured number, outside the stated range (below it).
By their numbers in this assay, from the lowest: compound 3; then compound 2; then compound 1.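

In this assay the position para to a large group on the six-membered aromatic ring of carbon only proves sensitive to its substituent: phenyl in place of chloro gives a large gain (a 13-fold lower number from compound 1 to compound 3 (1.10 log units; beyond the scatter)). For the compounds shown here, this is the first comparison that isolates one place, as compound 1 and compound 2 differ in more than one. Neither group counts any hydrogen-bond donors or acceptors, so the step arises without a change in those counts.

Open, going by these compounds, is whether the gain needs an aromatic ring here or would also follow from a benzyl group, a cyclohexyl group or a longer chain. Also open, on these data alone, is how an amine or a carboxylic acid on the added phenyl would behave. No measurement at hand accounts for the size of this step.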